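Moving the trifluoromethyl group on the aryl substituent

This account rests on a few compounds, and the source may have more. Where it says the series, first, only, none or still open, it means among the compounds named here.

In a functional assay on HeLa cells (Homo sapiens) for inhibition (a higher number here means a weaker inhibitor, a lower number a stronger inhibitor), compound 1 `Oc1ccc(-c2cc(-c3ccc(F)cc3)cc(-c3ccc(O)cc3)n2)cc1` gives 8680 nM. Compound 2 `Oc1ccc(-c2cc(-c3ccccc3C(F)(F)F)cc(-c3ccc(O)cc3)n2)cc1` carries 2-(trifluoromethyl)phenyl in place of 4-fluorophenyl on an aromatic carbon, and that step was an at least 5.7-fold higher number from compound 1 to compound 2 (0.76 log units; beyond the scatter). For compound 2 this assay reports only a limit, > 50000 nM, not a number. As far as these compounds go, the relevant reading is the limit of > 50000 nM in this assay, at which 1 of the 2 values shown sits, so the true standing of compound 2 above that line stays open.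

Compound 3 `Oc1ccc(-c2cc(-c3ccc(C(F)(F)F)cc3)cc(-c3ccc(O)cc3)n2)cc1` differs from compound 2 by 4-(trifluoromethyl)phenyl in place of 2-(trifluoromethyl)phenyl on an aromatic carbon; compound 3 thus carries 4-(trifluoromethyl)phenyl where compound 1 carries 4-fluorophenyl. Going by the values given here, the only measured step bearing on this is the one from compound 1 to compound 2, which changed both the substituent and its placement at once, so the two parts cannot be separated. Returning to the placement of compound 1 is expected to lower the number, an at least 3.3-fold lower number from compound 2 to compound 3 (0.52 log units; beyond the scatter), with size uncertain given the limit. The expected value for compound 3 is 15000 nM, within 5000 nM to 50000 nM.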

Compound 3, half-maximal inhibitory concentration: > 50000 nM
Compound 3 ended at the assay's limit (the forecaster's own chance of this, stated with the estimate: 25%); middle value at least 3.3-fold (0.52 log units) from the limit.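

In this assay compound 3 also gives only a limit, > 50000 nM. With the aryl substituent in the same place, trifluoromethyl in place of fluoro gives an at least 5.7-fold higher number from compound 1 to compound 3 (0.76 log units; beyond the scatter), so the earlier shift does not depend on the trifluoromethyl group sitting as in 2-(trifluoromethyl)phenyl. Going by these compounds alone, compound 1, with 4-fluorophenyl, remains the only compound here with a number, 8680 nM.

As far as these compounds go, whether 2-(trifluoromethyl)phenyl and 4-(trifluoromethyl)phenyl differ at all stays open, the step between compound 2 and compound 3 being unreadable with two limits: the limit of > 50000 nM in this assay, at which 2 of the 3 values shown sit. Also open is whether a chloro, methoxy or amine group on this phenyl ring would give a number under the limit, and whether any of them would give a lower number than compound 1.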